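The source may hold more compounds than are shown below. What is called first, only, known or untested is meant among the compounds shown, and "the series" means these compounds.

Values measured so far in an ADME assay on MRC5 cells (Homo sapiens), read by MTT assay, with a stated time of 72 h; on this read-out higher numbers stand for weaker inhibition and lower numbers for stronger inhibition:
- compound 1 `Cc1ncnc2c1c(-c1cc3ccccc3o1)cn2[C@@H]1O[C@H](CO)[C@@H](O)[C@H]1O`: 84400 nM
- compound 2 `C#Cc1cn([C@@H]2O[C@H](CO)[C@@H](O)[C@H]2O)c2ncnc(C)c12`: 1440 nM

Compound 2 holds the lower of the two numbers, and the gap to compound 1 lies beyond the scatter. The next compound to consider is compound 3 `Cc1ncnc2c1c(I)cn2[C@@H]1O[C@H](CO)[C@@H](O)[C@H]1O`, which changes the same aromatic carbon: iodo in place of ethynyl on an aromatic carbon. In short, iodo replaces ethynyl there.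

Among the compounds with values here, only one measured step bears on this change: a 59-fold lower number from compound 1 to compound 2 (1.77 log units; beyond the scatter). That large step came from putting ethynyl in place of 1-benzofuran-2-yl on this carbon, so the position clearly matters in this assay. Within the data shown here, it says nothing direct about iodo, however, and no measured compound carries that group. Neither iodo nor ethynyl brings a ring, so compound 3 is expected to stay closer to compound 2 than to compound 1. A moderate move towards a higher number is expected, though with wide uncertainty. The expected change is a 4.2-fold higher number from compound 2 to compound 3 (0.62 log units; beyond the scatter). For compound 3 the estimated value is 6000 nM, with an expected range from 1200 nM to 40000 nM.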

Compound 3, half-maximal inhibitory concentration: 13300 nM
Beside the measured number, compound 3's estimate is 2.2-fold (0.35 log units) below it, and the stated range covers the measured number.
By their numbers in this assay, from the lowest: compound 2; then compound 3; then compound 1.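

In this assay, this aromatic carbon of the five-membered ring now has three groups to compare, and iodo does not fall with either earlier compound: a 9.2-fold higher number from compound 2 to compound 3 (0.97 log units; beyond the scatter), while a 6.3-fold lower number from compound 1 to compound 3 (0.80 log units; beyond the scatter). Having no ring at this carbon is therefore not enough to fix the number, as ethynyl and iodo both lack a ring and still differ beyond the scatter, and removing the 1-benzofuran-2-yl ring accounts for only part of the span seen with ethynyl. No measurement shown here gives a reason for the gap between iodo and ethynyl, which differ in the triple bond and in heavy-atom count, so the order remains an observation only.

The compounds shown leave open where a hydrogen, an amine, a carboxylic acid or a longer alkyne chain on this carbon would fall relative to these three groups. On these data alone, all three compounds share the rest of the structure, so it also remains open whether this order would hold with a change elsewhere, such as replacing the methyl group on the core.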